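Removing the methoxy group from a weak inhibitor of cell growth

The source may hold more compounds than are shown below. What is called first, only, known or untested is meant among the compounds shown, and "the series" means these compounds.

Of the compounds shown here, three have been measured in a functional assay on MDA-MB-231 cells (Homo sapiens) for cytotoxicity, read by sulforhodamine B assay, with a stated time of 72 h; on this read-out lower numbers stand for stronger inhibition of growth and higher numbers for weaker inhibition of growth. Among the compounds with values here, compound 1 `O=C(Nc1ccccc1C(F)(F)F)C1CCc2ccccc2N1C(=O)c1cccc(Cl)c1` gives 288 nM, and compound 2 `CCCCCCCCC(=O)N1c2ccccc2CCC1C(=O)Nc1ccccc1C(F)(F)F` gives 3350 nM; the only single-point step among them, a 12-fold higher number from compound 1 to compound 2 (1.07 log units; beyond the scatter), concerns the group on the carbonyl carbon. Compound 3 `COc1ccc(NC(=O)C2CCc3ccccc3N2)cc1` gives 51400 nM in this assay, the highest number of the three and therefore the weakest inhibition of growth; it differs from compound 1 and compound 2 in more than one place, so its values are only compared, not explained.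

Compound 4 `O=C(Nc1ccccc1)C1CCc2ccccc2N1` is the next to be measured. It differs from compound 3 by hydrogen in place of methoxy on an aromatic carbon. Within the data shown here, no measured step touches this position or this group, so nothing among the measured compounds bears on the change directly. Without any relevant precedent, the expectation for the step in this assay is one of no shift beyond the scatter, in either direction: the estimated step is a 1.0-fold lower number from compound 3 to compound 4 (0.01 log units; within the scatter). Compound 4 is accordingly expected to give about 50000 nM in this assay, within a range from 15000 nM to 150000 nM, with a real possibility that the assay reports only a limit.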

Compound 4, concentration for 50% growth inhibition: 108000 nM
Beside the measured number, compound 4's estimate is 2.2-fold (0.33 log units) below it; measured number inside the range.
By their numbers in this assay, from the lowest: compound 1; then compound 2; then compound 3; then compound 4.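

In this assay, within the data shown here, this is the first reading at this position, on an aromatic carbon of a six-membered aromatic ring of carbon only, para to a large group: hydrogen in place of methoxy gives a 2.1-fold higher number from compound 3 to compound 4 (0.32 log units; beyond the scatter). The step is modest but printed as beyond the scatter, so growth inhibition is weaker without the methoxy group, and the change, which removes 2 heavy atoms and 1 hydrogen-bond acceptor, moves the number in one direction, though only by a small amount beside a 12-fold higher number from compound 1 to compound 2 (1.07 log units; beyond the scatter) at the other place. Nothing measured on these compounds accounts for the shift, and no outside finding bears on it.

The compounds shown leave open whether another group at this position, such as a hydroxyl, an amine or a carboxylic acid, would lower the number or raise it further, so a single pair gives a direction only for methoxy against hydrogen. They also leave open whether the same change would give a step of similar size on a compound carrying the trifluoromethyl group and the carbonyl-linked groups found in compound 1 and compound 2.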